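A few compounds are considered here, and "the series" means these few. Any claim that something is new, unique, unknown or untested is made for them only; others in the source may bear on it.

Of the compounds shown here, two have been measured so far in a functional assay on U-251 cells (Homo sapiens) for inhibition, read by sulforhodamine B assay, with a stated time of 48 h; a lower number here means a stronger inhibitor of growth, a higher number a weaker inhibitor of growth. Compound 1 `N#C/C(=C\N1CCN(C(=O)c2ccco2)C1=S)C(=O)c1ccccc1` gives 17000 nM in this assay. Compound 2 `O=CN1CCN(c2ccc(Cl)cc2)C1=S` gives 14400 nM in this assay; this is the lower of the two numbers, yet the gap to compound 1 lies within the usual scatter, so on these figures the two compounds cannot be told apart. Compound 3 `O=CN1CCN(c2ccc(Cl)c(Cl)c2)C1=S` has not yet been measured. It differs from compound 2 in one place: chloro in place of hydrogen on an aromatic carbon. Within the data shown here, no measured pair in this set shares that change, and nothing here shows how large a step it produces or in which direction. The two measured values, being so close, offer no guidance either, and the expectation for compound 3 rests on the structural change alone. A single added chlorine is a small change, and the step is expected to stay within the scatter, leaning slightly toward a lower number. The estimated step from compound 2 to compound 3 is a 1.4-fold lower number from compound 2 to compound 3 (0.16 log units; within the scatter). For compound 3 the expected value in this assay is 10000 nM, with a range from 4000 nM to 30000 nM.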

Compound 3, concentration for 50% growth inhibition: 12500 nM
The estimate for compound 3 lay 1.3-fold (0.10 log units) below the measured number; measured number inside the range.
By their numbers in this assay, from the lowest: compounds 3, 2 and 1 (each within the scatter of the next).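

Among these compounds, the first pair in this set that differs in only one place tests a chloro group on the aromatic carbon ortho to a chloro group and meta to a group of 8 heavy atoms. In this assay, the result is a 1.2-fold lower number from compound 2 to compound 3 (0.06 log units; within the scatter), so on this core a hydrogen and a chloro group at this position cannot be told apart by this read-out. No measurement here offers an explanation for this result.

One pair cannot show whether this position accepts other groups equally well: a methoxy group, an amine or a carboxylic acid at the same carbon might give a step of any size or in either direction. Going by these compounds, it also remains open whether the same chloro change would give a similarly small step on the core of compound 1, or whether a chloro group at another carbon of this ring would do the same.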